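This account rests on a few compounds, and the source may have more. Where it says the series, first, only, none or still open, it means among the compounds named here.

Measured in a functional assay on MCF7 cells (Homo sapiens) for antiproliferative activity, read by MTT assay, with a stated time of 48 h; on this read-out higher numbers stand for weaker inhibition and lower numbers for stronger inhibition:
- Compound 1 `COc1ccc(-c2c(Nc3ccc(C)cc3)c3ccc(O)cc3oc2=O)cc1`: 85500 nM
- Compound 2 `COc1ccc(Nc2c(C(=O)C(F)(F)F)c(=O)oc3ccc(OC)cc23)cc1`: > 100000 nM

For compound 2, the entry > 100000 nM is a limit of the assay and not a number. Compound 3 `COc1ccc2oc(=O)c(C(=O)C(F)(F)F)c(Nc3ccc(C)c(O)c3)c2c1` has the same atoms as compound 2, joined differently: 3-hydroxy-4-methylphenyl in place of 4-methoxyphenyl on a nitrogen on an aromatic ring. In words, 3-hydroxy-4-methylphenyl replaces 4-methoxyphenyl on a nitrogen on an aromatic ring. Going by the values given here, no measured pair shows the effect of this swap in this assay. Among the compounds with values here, the one exact number, compound 1 at 85500 nM, is also weak inhibition, so only a small gain is expected. The expected change is an at least 1.2-fold lower number from compound 2 to compound 3 (0.09 log units; that floor lies within the scatter). For compound 3, the estimated value is 80000 nM, with an expected range of 30000 nM to 200000 nM.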

Compound 3, half-maximal inhibitory concentration: 20100 nM
Estimate against measurement, compound 3: 4.0-fold (0.60 log units) above; the whole stated range lies above it.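

Changing the group on the nitrogen shows that this position can change the result in this assay: the swap gives an at least 4.9-fold lower number from compound 2 to compound 3 (0.69 log units; beyond the scatter). The entering group has a hydrogen-bond donor and the leaving group has none, but this single swap cannot show which feature counts. The step has no exact size, because compound 2 stands at a limit of the assay: the limit of > 100000 nM in this assay, at which 1 of the 3 values shown sits.

Going by these compounds, it remains open whether the hydroxy group or the methyl group alone would give the same change. Also open, on these data alone, is how a carboxylic acid or a longer chain in place of the hydroxy group would read.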